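Shortening the Chain Once More: Compound 3

A few compounds are considered here, and "the series" means these few. Any claim that something is new, unique, unknown or untested is made for them only; others in the source may bear on it.

Among the compounds with values here, compound 2 `COc1cc2nc(N3CCN(C(=O)CC4CCSS4)CC3)nc(N)c2cc1OC` holds the lowest number of the two measured so far in a functional assay on spleen for antagonist activity at Alpha-1B adrenergic receptor (Rattus norvegicus); a lower number here means tighter binding, a higher number weaker binding; compound 2 gives 1.02 nM. Compound 1 `COc1cc2nc(N3CCN(C(=O)CCCCC4CCSS4)CC3)nc(N)c2cc1OC` gives 40.7 nM. Within the data shown here, the one measured step, a 40-fold lower number from compound 1 to compound 2 (1.60 log units; beyond the scatter), came with a shorter chain. Compound 3 `COc1cc2nc(N3CCN(C(=O)C4CCSS4)CC3)nc(N)c2cc1OC` carries that change further: a group of 5 heavy atoms (3 carbon, 2 sulfur; one five-membered non-aromatic ring with 2 hetero atoms) in place of a group of 6 heavy atoms (4 carbon, 2 sulfur; one five-membered non-aromatic ring with 2 hetero atoms), on a carbonyl carbon. Among the measured compounds shown here, only this single step bears on it, and it points toward a smaller number, though a further shortening need not repeat it. A modest change, if any, is expected, a 1.3-fold lower number from compound 2 to compound 3 (0.11 log units; within the scatter). Compound 3 is therefore estimated at 0.8 nM, within 0.15 nM to 4 nM.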

Compound 3, dissociation constant: 1.74 nM
Estimate against measurement, compound 3: 2.2-fold (0.34 log units) below; the measured number falls inside the stated range.
By their numbers in this assay, from the lowest: compounds 2 and 3 (each within the scatter of the next); then compound 1.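

In this assay, the group of 5 heavy atoms on the carbonyl carbon, in place of the group of 6, gives a 1.7-fold higher number from compound 2 to compound 3 (0.23 log units; within the scatter) and so cannot be told apart from it. The large drop seen on shortening the chain of compound 1 therefore does not continue at this length, although a 23-fold lower number from compound 1 to compound 3 (1.37 log units; beyond the scatter) remains. No measured evidence here explains this levelling off.

Still open, as far as these compounds go, is whether the sulfur-containing ring itself matters, which a plain cyclopentyl ring on the same carbonyl carbon would test. From the compounds shown here alone, the effect of a chain of other lengths also remains open.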